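The source may hold more compounds than are shown below. What is called first, only, known or untested is meant among the compounds shown, and "the series" means these compounds.

Compound 3, with structure `CC1(C)CC(=O)C2=C(C1)NC(c1ccccc1)=CC2c1ccc(Cl)cc1`, gives 7.16% in an assay on isolated protein for inhibition of glucose-6-phosphatase catalytic subunit 1 (Homo sapiens), read by inositol phosphate accumulation, with a stated time of 30 min, tested at 100 uM (on this read-out lower numbers stand for less inhibition and higher numbers for more inhibition at the one concentration tested (going by the name of the read-out)), the lower of the two numbers recorded. Its nearest neighbour is compound 2, `O=C1CCCC2=C1C(c1ccc(Cl)cc1)C=C(c1ccccc1)N2`, whose result in this assay is 8.21%, a gap that lies within the scatter. Compound 1, `CCOC(=O)C1(O)CC(c2ccc(F)cc2)C2=C(CC(C)(C)CC2=O)O1`, is reported in this assay only as "not active" (no number reported), with no number attached. Compound 4, `COc1ccc(C2C=C(c3ccccc3)NC3=C2C(=O)CC(C)(C)C3)cc1`, has not yet been measured; it differs from compound 3 in one place, (methoxy in place of chloro on an aromatic carbon). Among the measured compounds shown here, no step between measured compounds bears on this change, so the expected shift of a number 0.2 percentage points lower from compound 3 to compound 4 (within the scatter) is none beyond the scatter. Compound 4 is therefore estimated at 7% in this assay, with a range from -3% to 17%.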

Compound 4, a percentage reported as inhibition, at one concentration (the size of the read-out at that concentration, not a potency): "not active" (no number reported)
For compound 4 the study gives words and no number; there is nothing to compare the estimate with.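

Among the compounds shown here, compound 4 carries only words and no number, so no step from compound 3 to compound 4 can be read. Nothing available explains this result. The compounds shown leave open how far changing 4-chlorophenyl to 4-methoxyphenyl shifts inhibition.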